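This account rests on a few compounds, and the source may have more. Where it says the series, first, only, none or still open, it means among the compounds named here.

Of the compounds shown here, two of a shared core have been tested in a functional assay on MDA-MB-231 cells (Homo sapiens) for cytotoxicity, read by sulforhodamine B assay, tested at 10 uM; on this read-out higher numbers stand for more inhibition at the one concentration tested (going by the name of the read-out) and lower numbers for less inhibition. Compound 1 `CCc1ccc(-c2cc(-c3cn([C@H]4C[C@H](OC(C)=O)[C@@H](COC(C)=O)O4)c(=O)[nH]c3=O)on2)cc1` gives 97.4% there. Compound 2 `CC(=O)OC[C@H]1O[C@@H](n2cc(-c3cc(C)no3)c(=O)[nH]c2=O)C[C@@H]1OC(C)=O` gives 106% in this assay. Compound 2 holds the higher of the two numbers, but the gap, a number 8.6 percentage points higher from compound 1 to compound 2 (within the scatter), is within the scatter, so the two compounds cannot be told apart on this read-out.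

Compound 3 `CCCCc1ccc(-c2cc(-c3cn([C@H]4C[C@H](OC(C)=O)[C@@H](COC(C)=O)O4)c(=O)[nH]c3=O)on2)cc1` is now considered. It differs from compound 2 in one place: 4-butylphenyl in place of methyl on an aromatic carbon. Within the data shown here, the only measured step that bears on this change is the one from compound 1 to compound 2, which swapped a 4-ethylphenyl for a methyl and moved the number by a number 8.6 percentage points higher from compound 1 to compound 2 (within the scatter), within the scatter. Going back from methyl to a 4-butylphenyl is therefore expected to shift this assay by about a number 6 percentage points lower from compound 2 to compound 3 (within the scatter), that is, no step beyond the scatter. For compound 3 the expected value in this assay is 100%, with a likely range from 85% to 110%.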

Compound 3, a percentage reported as inhibition, at one concentration (the size of the read-out at that concentration, not a potency): 72.2%
For compound 3 the middle estimate is 27.8 percentage points above the measured one; measured number below the stated range.
By their numbers in this assay, from the lowest: compound 3; then compounds 1 and 2 (each within the scatter of the next).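

In this assay, this position on the five-membered aromatic ring turns out to be sensitive to what it carries: 4-butylphenyl in place of methyl goes with a number 33.8 percentage points lower from compound 2 to compound 3 (beyond the scatter), whereas the earlier swap between methyl and 4-ethylphenyl stayed within the scatter. Lengthening only the chain on the phenyl ring, from 4-ethylphenyl to 4-butylphenyl, goes with a number 25.2 percentage points lower from compound 1 to compound 3 (beyond the scatter), so the phenyl ring alone does not account for the drop, as compound 1 carries that ring too. No measurement at hand explains why the longer chain lowers the number.

Going by these compounds, whether a still longer chain such as hexyl would lower the number further remains open. So does the outcome with an amine or a carboxylic acid at the end of the chain.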